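Chloro for trifluoromethyl on the urea aryl ring

The source may report more compounds than this note shows. Statements on the series, on what has been measured and on what is new or still open speak of the compounds shown alone.

Measured so far:
compound 1 `O=C(Nc1cccc(-n2cc(-c3ccncc3)c(-c3cc(O)cc(Cl)c3)n2)c1)Nc1ccc(Cl)c(Cl)c1`: -78%
compound 2 `COc1cc(Cl)cc(-c2nn(-c3cccc(NC(=O)Nc4ccc(Cl)c(C(F)(F)F)c4)c3)cc2-c2ccncc2)c1`: -77%

Of the compounds shown here, two have been tested in a functional assay on SK-MEL-5 cells (Homo sapiens) for inhibition, read by sulforhodamine B assay, with a stated time of 48 h, tested at 100 uM; a higher number here means a weaker effect of the compound at the concentration tested, a lower number a stronger effect. Compound 1 `O=C(Nc1cccc(-n2cc(-c3ccncc3)c(-c3cc(O)cc(Cl)c3)n2)c1)Nc1ccc(Cl)c(Cl)c1` gives -78%. Compound 2 `COc1cc(Cl)cc(-c2nn(-c3cccc(NC(=O)Nc4ccc(Cl)c(C(F)(F)F)c4)c3)cc2-c2ccncc2)c1` gives -77%. Among these two numbers compound 2 stands highest, but its nearest neighbour, compound 1, lies only a hair lower, a gap within the usual scatter of this assay, so the two compounds cannot be told apart on these data.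

Compound 3 `COc1cc(Cl)cc(-c2nn(-c3cccc(NC(=O)Nc4ccc(Cl)c(Cl)c4)c3)cc2-c2ccncc2)c1` has not yet been measured in this assay. It differs from compound 2 in a single place: chloro in place of trifluoromethyl on an aromatic carbon. Among the compounds with values here, no step between two measured compounds isolates this exchange, so nothing measured tells how large its effect should be. Compound 1 already carries a 3,4-dichlorophenyl on the urea and reads much like compound 2, which is the only hint available.

On that basis compound 3 is expected to stay close to compound 2, with a step of a number 1 percentage points higher from compound 2 to compound 3 (within the scatter) that should not exceed the scatter. The value expected for compound 3 in this assay is -76%, within a range from -90% to -55%.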

Compound 3, a percentage reported as activity, at one concentration (the size of the read-out at that concentration, not a potency): -68%
For compound 3 the middle estimate is 8 percentage points below the measured one, within the range that was stated.
By their numbers in this assay, from the lowest: compounds 1, 2 and 3 (each within the scatter of the next).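

The exchange now has a measured size: on the aromatic carbon ortho to a chloro group, trifluoromethyl gives way to chloro with this assay reading a number 9 percentage points higher from compound 2 to compound 3 (within the scatter), so this position tolerates the smaller group without a step that can be told from the scatter. Within the data shown here, compound 3 also supplies the first step at the oxygen on the aromatic ring, with the 3,4-dichlorophenyl held constant: placing methyl on that oxygen in place of hydrogen, read in the direction from the methyl-free compound, gives a number 10 percentage points higher from compound 1 to compound 3 (within the scatter), again a step that the scatter cannot separate from no change at all. Nothing on hand explains either step.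

The three compounds therefore leave open whether a nitrile, a methyl or a plain hydrogen on that aromatic carbon, or an ethyl or a longer chain on the oxygen, would give a step beyond the scatter. These readings also come from a single concentration, so they show the size of the effect at that concentration and nothing beyond it.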